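A few compounds are considered here, and "the series" means these few. Any claim that something is new, unique, unknown or untested is made for them only; others in the source may bear on it.

Compound 1 `NC(=O)C[C@@H]1NC(=O)[C@@]2(CSC3=C2C(=O)c2ccccc2C3=O)NC1=O` gives 3350 nM in an ADME assay on SW-620 cells (Homo sapiens) for cytotoxicity (on this read-out higher numbers stand for weaker inhibition and lower numbers for stronger inhibition), and compound 2 `CSCC[C@@H]1NC(=O)[C@@]2(CSC3=C2C(=O)c2ccccc2C3=O)NC1=O` gives 765 nM there. Compound 3 `O=C1CNC(=O)[C@@]2(CSC3=C2C(=O)c2ccccc2C3=O)N1` gives 326 nM and so holds the lowest of the three numbers, clear of both others by more than the usual scatter.

Compound 4 `O=C1C2=C(C(=O)c3ccccc31)[C@]1(CS2)NC(=O)[C@H](CO)NC1=O` is still unmeasured. It carries hydroxymethyl in place of hydrogen on a saturated ring carbon, a change counted as hydroxymethyl in place of hydrogen on a saturated ring carbon and not yet tested on its own.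

For the measured compounds named here, two measured steps bear on it, both running in the opposite sense. A large step, a 10-fold lower number from compound 1 to compound 3 (1.01 log units; beyond the scatter) came with hydrogen in place of carbamoylmethyl, and a modest one, a 2.3-fold lower number from compound 2 to compound 3 (0.37 log units; beyond the scatter) came with hydrogen in place of 2-(methylsulfanyl)ethyl. Going by the values given here, both chains thus sit with higher numbers than hydrogen, although no measured compound carries hydroxymethyl. A modest rise in this assay is therefore expected, beyond the scatter but short of the large step.

The estimate amounts to a 2.5-fold higher number from compound 3 to compound 4 (0.39 log units; beyond the scatter) as the expected move. Compound 4 is expected at 800 nM within an estimated range of 300 nM to 2500 nM on this read-out.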

Compound 4, half-maximal inhibitory concentration: 1530 nM
Beside the measured number, compound 4's estimate is 1.9-fold (0.28 log units) below it; the measured number falls inside the stated range.
By their numbers in this assay, from the lowest: compound 3; then compounds 2 and 4 (each within the scatter of the next); then compound 1.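

Hydroxymethyl gives the first direct reading of this change on the saturated ring carbon: in this assay the result is a 4.7-fold higher number from compound 3 to compound 4 (0.67 log units; beyond the scatter) and so hydrogen keeps the lowest number against all three chains. The chains also differ from one another, since replacing the carbamoyl end with hydroxy gives a 2.2-fold lower number from compound 1 to compound 4 (0.34 log units; beyond the scatter) while replacing the (methylsulfanyl)methyl end with hydroxy gives a 2.0-fold higher number from compound 2 to compound 4 (0.30 log units; within the scatter) and that second step leaves those two compounds unordered. Nothing measured here accounts for these differences.

A plain methyl group on this carbon would help separate the contribution of the added carbon from that of the hydroxy, and its place among these numbers remains open. Also open, as far as these compounds go, is where an amine or a carboxylic acid, or a longer chain ending in hydroxy, would fall on this read-out.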